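The compounds below may be only part of what the source reports. "The series", "measured", "known", "first", "only" and "open" are said of these compounds alone.

In a functional assay on A549 cells (Homo sapiens) for antiproliferative activity, read by MTT assay, with a stated time of 72 h (on this read-out lower numbers stand for stronger inhibition and higher numbers for weaker inhibition), two compounds sharing the same core have been measured so far. Compound 1 `CC(C)(C)OC(=O)N1CCN(C(=S)Sc2cccc(Cl)c2)CC1` gives 634 nM, while compound 2 `Cc1ccccc1SC(=S)N1CCN(C(=O)OC(C)(C)C)CC1` gives 2270 nM, the higher of the two numbers and so the weaker inhibition. Compound 3 `CC(C)(C)OC(=O)N1CCN(C(=S)Sc2ccccc2Cl)CC1` has not yet been measured. It has chloro in place of methyl on an aromatic carbon of compound 2, ortho to a large group: chloro in place of methyl on an aromatic carbon. Within the data shown here, one measured step bears on this change: a 3.6-fold higher number from compound 1 to compound 2 (0.55 log units; beyond the scatter), a modest step beyond the scatter, with 2-methylphenyl in place of 3-chlorophenyl on a sulfur. Among the measured compounds shown here, that step alters more than the one group, so it is only a partial guide. A modest move to a lower number is therefore expected in this assay, with an expected size of a 2.3-fold lower number from compound 2 to compound 3 (0.36 log units; beyond the scatter). For compound 3, the estimated value is 1000 nM, within an expected range of 350 nM to 2900 nM.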

Compound 3, half-maximal inhibitory concentration: 1560 nM
Compound 3: the middle estimate sits 1.6-fold (0.19 log units) below what was measured, and the stated range covers the measured number.
By their numbers in this assay, from the lowest: compound 1; then compounds 3 and 2 (each within the scatter of the next).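

In this assay, the change from 2-methylphenyl to 2-chlorophenyl, on an aromatic carbon ortho to a large group, gives a 1.5-fold lower number from compound 2 to compound 3 (0.16 log units; within the scatter), so methyl and chloro cannot be told apart at this place. Keeping the chloro and changing only its place, with 2-chlorophenyl in place of 3-chlorophenyl on the sulfur, gives a 2.5-fold higher number from compound 1 to compound 3 (0.39 log units; beyond the scatter), so among these three compounds the place of the substituent separates the values, while the exchange of methyl for chloro does not. Nothing available here explains this difference.

The compounds shown leave open whether a 3-methylphenyl group would match the 3-chlorophenyl group of compound 1 as closely as the two ortho groups match each other. They also leave open how a larger or charged group, such as a methoxy group, an amine or a carboxylic acid, would read at either place.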